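Compound 3 and the step to compound 4

The source may hold more compounds than are shown below. What is called first, only, known or untested is meant among the compounds shown, and "the series" means these compounds.

Compound 1 `CCn1c(N)c(-c2nc3ccccc3[nH]2)c2nc(C#N)c(C#N)nc21` gives > 50000 nM as a limit of the assay
Compound 2 `CN(C)CCn1c(N)c(-c2nc3ccccc3[nH]2)c2nc(C#N)c(C#N)nc21` gives 8320 nM
Compound 3 `N#Cc1nc2c(-c3nc4ccccc4[nH]3)c(N)n(CCO)c2nc1C#N` gives 5520 nM

In a functional assay on Raji cells (Homo sapiens) for antiproliferative activity, read by MTT assay, with a stated time of 48 h (on this read-out lower numbers stand for stronger inhibition and higher numbers for weaker inhibition), compound 3 holds no rank of its own, as the gap a 1.5-fold lower number from compound 2 to compound 3 (0.18 log units; within the scatter) lies within the scatter. Against the limit of compound 1, the steps of an at least 6.0-fold lower number from compound 1 to compound 2 (0.77 log units; beyond the scatter) and an at least 9.0-fold lower number from compound 1 to compound 3 (0.95 log units; beyond the scatter) lie beyond the scatter. Compound 4 `CN(C)CCCn1c(N)c(-c2nc3ccccc3[nH]2)c2nc(C#N)c(C#N)nc21` departs from compound 3 by (dimethylamino)methyl in place of hydroxy on a saturated chain carbon, two bonds along the chain from an aromatic nitrogen with (dimethylamino)methyl in place of hydroxy on a saturated chain carbon, two bonds along the chain from an aromatic nitrogen. The nearest guide is the swap of dimethylamino for hydroxy in compound 3 a 1.5-fold lower number from compound 2 to compound 3 (0.18 log units; within the scatter) which stayed within the scatter, so no step beyond it is expected. The expected change is a 1.1-fold higher number from compound 3 to compound 4 (0.04 log units; within the scatter) and no more. For compound 4 the estimate is 6000 nM with 2200 nM to 18000 nM as its expected range.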

Compound 4, half-maximal inhibitory concentration: 1230 nM
Estimate against measurement, compound 4: 4.9-fold (0.69 log units) above; measured number below the stated range.
By their numbers in this assay, from the lowest: compound 4; then compounds 3 and 2 (each within the scatter of the next). At a limit, above all of these: compound 1.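

At this place on the chain, the 3-(dimethylamino)propyl group of compound 4 stands apart from the 2-hydroxyethyl group of compound 3 and the 2-(dimethylamino)ethyl group of compound 2, whose values lie within the scatter of each other: this assay shows a 4.5-fold lower number from compound 3 to compound 4 (0.65 log units; beyond the scatter) and a 6.8-fold lower number from compound 2 to compound 4 (0.83 log units; beyond the scatter). With the dimethylamino group kept, lengthening the chain therefore changes the number, whereas replacing that group with hydroxy on the shorter chain did not. The comparison with compound 1 rests on a limit, giving an at least 40-fold lower number from compound 1 to compound 4 (1.60 log units; beyond the scatter): the limit of > 50000 nM in this assay, at which 1 of the 4 values shown sits.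

From the compounds shown here alone, whether the 3-hydroxypropyl group would match compound 4 remains open, so chain length and the amine cannot yet be separated on the longer chain. Also open, going by these compounds, is how a longer chain ending in dimethylamino, or a primary amine on the same chain, would compare.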